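A few compounds are considered here, and "the series" means these few. Any claim that something is new, unique, unknown or untested is made for them only; others in the source may bear on it.

Measured compounds:
Compound 1 `CC(C)Cc1ccc(C(C)C(=O)NCc2ccc(F)cc2)cc1`: 27000 nM
Compound 2 `CC(C)Cc1ccc(C(C)C(=O)N2CCN(c3ccccc3)CC2)cc1`: 4700 nM

Of the two compounds measured in an assay on brain for inhibition of Fatty-acid amide hydrolase 1 (Rattus norvegicus), read by scintillation counting, with a stated time of 10 min (a lower number here means a stronger inhibitor, a higher number a weaker inhibitor), compound 2 gives the lower number, 4700 nM, while compound 1 gives 27000 nM; the gap between them lies beyond the scatter. Among the measured compounds shown here, no step between measured compounds that differ in one place exists here, so the effect of a single change on the shared core cannot be read off directly.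

Compound 3 `CC(C)Cc1ccc(C(C)C(=O)N2CCN(c3cccc(Cl)c3)CC2)cc1` is not yet measured. It differs from compound 2 in one place: chloro in place of hydrogen on an aromatic carbon, on an aromatic carbon of a six-membered aromatic ring of carbon only, meta to a large group. For the measured compounds named here, no measured pair shows what such a change does in this assay. The step from compound 2 to compound 3 is expected to be small, likely within the scatter or a modest lowering, estimated as a 1.6-fold lower number from compound 2 to compound 3 (0.19 log units; within the scatter). Compound 3 is therefore expected to give about 3000 nM, within a range from 1000 nM to 10000 nM.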

Compound 3, half-maximal inhibitory concentration: 1700 nM
Compound 3: the middle estimate sits 1.8-fold (0.25 log units) above what was measured; the measured number falls inside the stated range.
By their numbers in this assay, from the lowest: compound 3; then compound 2; then compound 1.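

In this assay, among the compounds shown here, the change from phenyl to 3-chlorophenyl gives a 2.8-fold lower number from compound 2 to compound 3 (0.44 log units; beyond the scatter) and so supplies the first step between compounds that differ in one place. It shows that this six-membered aromatic ring responds to substitution: a single chloro, meta to a large group, moves the number beyond the scatter and toward a stronger inhibitor. No independent data bear on why this step occurs.

Going by these compounds, whether the lowering belongs to chloro itself or would also come with another group at this place, such as fluoro, methyl or methoxy, stays open. Also open, on these data alone, is whether chloro elsewhere on the same ring, or a second chloro added to it, would lower the number further, leave it within the scatter or raise it.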